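Acylated glycosyl thiadiazoles: unsaturated chain extension on breast cancer cells

This account rests on a few compounds, and the source may have more. Where it says the series, first, only, none or still open, it means among the compounds named here.

Compound 1 `CCCCCCCCCCCC(=O)Nc1nnc(S[C@@H]2O[C@H](COC(C)=O)[C@H](OC(C)=O)[C@H](OC(C)=O)[C@H]2OC(C)=O)s1` and compound 2 `CCCCCCCCCCCCCC(=O)Nc1nnc(S[C@@H]2O[C@H](COC(C)=O)[C@H](OC(C)=O)[C@H](OC(C)=O)[C@H]2OC(C)=O)s1` share the same acetylated sugar and thiadiazole core and differ only in the length of the saturated acyl chain. In a functional assay on MDA-MB-231 cells (Homo sapiens) for cytotoxicity, read by MTT assay, with a stated time of 24 h (on this read-out lower numbers stand for stronger inhibition and higher numbers for weaker inhibition), compound 1 gives 26700 nM, and compound 2 gives 26200 nM. The step of a 1.0-fold lower number from compound 1 to compound 2 (0.01 log units; within the scatter) shows that the longer chain leaves the number unchanged within the scatter, so compound 2 stands beside compound 1 rather than apart from it.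

Compound 3 `CCCCCCCC/C=C\CCCCCCCC(=O)Nc1nnc(S[C@@H]2O[C@H](COC(C)=O)[C@H](OC(C)=O)[C@H](OC(C)=O)[C@H]2OC(C)=O)s1` carries the change (dec-1-en-1-yl in place of hexyl on a saturated chain carbon, seven bonds along the chain from a carbonyl carbon). Going by the values given here, the only measured step that bears on it is the chain extension from compound 1 to compound 2, which was flat; no measured pair shows the effect of a double bond. Compound 3 is therefore expected to sit close to compound 2, with the step of a 1.0-fold lower number from compound 2 to compound 3 (0.02 log units; within the scatter) estimated to stay within the scatter. The estimate for compound 3 in this assay is 25000 nM, with a range of 10000 nM to 60000 nM.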

Compound 3, half-maximal inhibitory concentration: 23600 nM
The estimate for compound 3 lay 1.1-fold (0.03 log units) above the measured number; low and high end bracket the measured number.
By their numbers in this assay, from the lowest: compounds 3, 2 and 1 (each within the scatter of the next).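

In this assay, dec-1-en-1-yl in place of hexyl on a saturated chain carbon, seven bonds along the chain from a carbonyl carbon, gives a step within the scatter (a 1.1-fold lower number from compound 2 to compound 3 (0.05 log units; within the scatter)), and dec-1-en-1-yl in place of butyl gives the same reading (a 1.1-fold lower number from compound 1 to compound 3 (0.05 log units; within the scatter)). The flat response thus extends from the saturated chains of compound 1 and compound 2 to a chain with one double bond outside aromatic rings, though all three numbers remain close together. No supporting measurement bears on this flat result.

A saturated chain matching the length of compound 3 would separate the double bond from the added carbons. Going by these compounds, a terminal amine or carboxylic acid on the chain remains open at this position, as does a much longer chain.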